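A few compounds are considered here, and "the series" means these few. Any claim that something is new, unique, unknown or untested is made for them only; others in the source may bear on it.

Working notes on the group carried on the aromatic nitrogen of the shared core. In a functional assay on DU-145 cells (Homo sapiens) for inhibition, read by trypan blue exclusion, with a stated time of 72 h (a lower number here means a stronger inhibitor, a higher number a weaker inhibitor), compound 1 (`COC(=O)Cn1c(=O)c(S(=O)(=O)c2ccc(F)cc2F)cc2cnc(Nc3ccc4[nH]ccc4c3)nc21`) gives 10000 nM and compound 2 (`CCCn1c(=O)c(S(=O)(=O)c2ccc(F)cc2F)cc2cnc(Nc3ccc4[nH]ccc4c3)nc21`) gives 1000 nM while compound 3 (`O=c1c(S(=O)(=O)c2ccc(F)cc2F)cc2cnc(Nc3ccc4[nH]ccc4c3)nc2n1C1CC1`) gives 500 nM in this set. Compound 3 stands with compound 2 at the low end of the numbers: a 2.0-fold lower number from compound 2 to compound 3 (0.30 log units; within the scatter) lies within the scatter, whereas a 20-fold lower number from compound 1 to compound 3 (1.30 log units; beyond the scatter) is large.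

Compound 4 (`O=c1c(S(=O)(=O)c2ccc(F)cc2F)cc2cnc(Nc3ccc4[nH]ccc4c3)nc2n1C1CCCCC1`) has cyclohexyl in place of cyclopropyl on an aromatic nitrogen and is otherwise unchanged. The step of a 10-fold lower number from compound 1 to compound 2 (1.00 log units; beyond the scatter) is modest, and like the large step it concerns the loss of the methoxycarbonyl group, which neither compound 3 nor compound 4 holds, so both bear only weakly here. Among the measured compounds shown here, the nearest precedent is the exchange of propyl for cyclopropyl, a 2.0-fold lower number from compound 2 to compound 3 (0.30 log units; within the scatter) and thus no larger than the scatter. For the measured compounds named here, no measured compound carries a larger ring at this place, so the direction remains poorly supported.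

No step beyond the scatter is expected in this assay and only a slight lean towards a lower number is held. The estimated step is a 1.7-fold lower number from compound 3 to compound 4 (0.22 log units; within the scatter) and it carries wide uncertainty. For compound 4 the expected value is 300 nM with 70 nM to 1500 nM as the estimated range.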

Compound 4, half-maximal inhibitory concentration: 10000 nM
Estimate against measurement, compound 4: 33-fold (1.52 log units) below; measured number above the stated range.
By their numbers in this assay, from the lowest: compounds 3 and 2 (each within the scatter of the next); then compounds 1 and 4 (each within the scatter of the next).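

At this position the size of a carbon-only ring counts in this assay: with the three-membered ring of cyclopropyl replaced by the six-membered ring of cyclohexyl, there is a 20-fold higher number from compound 3 to compound 4 (1.30 log units; beyond the scatter), although neither group carries a hydrogen-bond donor or acceptor. Among the compounds shown here, until now, the only steps beyond the scatter involved loss of the methoxycarbonyl group, but a 10-fold higher number from compound 2 to compound 4 (1.00 log units; beyond the scatter) shows that cyclohexyl also separates from propyl, and no change at the digits printed from compound 1 to compound 4 (within the scatter) places cyclohexyl level with the (methoxycarbonyl)methyl group, so a high number on this nitrogen does not depend on an ester. No evidence on hand bears on what lies behind the jump from cyclopropyl to cyclohexyl.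

The compounds shown leave open where between the three-membered and six-membered rings the number rises, and whether cyclobutyl or cyclopentyl would fall with compound 3 or with compound 4. Also open, from the compounds shown here alone, is whether the rise follows ring size alone or the carbon count more generally, which a longer chain such as butyl or hexyl on the same nitrogen would test against the propyl of compound 2.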